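The source may report more compounds than this note shows. Statements on the series, on what has been measured and on what is new or still open speak of the compounds shown alone.

Compound 1 `O=C(Nc1ccc(Br)cc1)c1c(NO)cc(-c2ccccc2)oc1=O`: in an ADME assay on Huh-7 cells (Homo sapiens) for cytotoxicity, read by a luciferase reporter and WST assay, with a stated time of 3 days (on this read-out lower numbers stand for higher toxicity in this test and higher numbers for lower toxicity in this test), compound 1 gives > 20000 nM, which is a limit of the assay and not a number.
Compound 2 `Cc1ccccc1NC(=O)c1c(NO)cc(-c2ccccc2)oc1=O`: in this assay compound 2 gives > 20000 nM, again a limit of the assay.
Compound 3 `Cc1cccc(NC(=O)c2c(NO)cc(-c3ccccc3)oc2=O)c1`: in this assay compound 3 gives > 20000 nM, again a limit of the assay.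

Compound 3 therefore stands only at a limit, and nothing in the numbers tells how far beyond that limit its true value lies. The two other measured compounds stand at the same point, so the whole measured set sits at the limit of > 20000 nM in this assay, at which 3 of the 3 values shown sit.

Compound 4 `CNC(=O)c1c(NO)cc(-c2ccccc2)oc1=O` differs from compound 3 in one place: methyl in place of 3-methylphenyl on an amide-type nitrogen. The measured steps that could guide this change are a step that the two limits leave unreadable from compound 1 to compound 3 and a step that the two limits leave unreadable from compound 2 to compound 3, with a step that the two limits leave unreadable from compound 1 to compound 2 between the other two aryl amides. All three are unreadable because the limit of > 20000 nM in this assay, at which 3 of the 3 values shown sit, holds for every value shown. None of them swaps the aryl group for a methyl, and none gives a size, so no direction can be read from them.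

The expectation rests only on every measured compound sitting at the limit. Compound 4 is expected to give 30000 nM in this assay. The expected range for compound 4 runs from 12000 nM to 100000 nM. The expected step is a step that the limit leaves unreadable from compound 3 to compound 4, most likely reported as another limit rather than a number.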

Compound 4, half-maximal cytotoxic concentration: > 20000 nM
Compound 4: a limit, no number; the forecaster's own chance of this, stated with the estimate: 80%; the middle value does not contradict the limit.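

Compound 4 also gives a limit and not a number, so its steps from compound 1, compound 2 and compound 3 cannot be read, and the whole set stands at one point: the limit of > 20000 nM in this assay, at which 4 of the 4 values shown sit. The compounds shown leave open how far each true value lies past that limit, and whether the group on the amide-type nitrogen matters at all in this assay.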